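Dropping the carboxy group from a thioether side chain

The compounds below may be only part of what the source reports. "The series", "measured", "known", "first", "only" and "open" are said of these compounds alone.

Measured compounds:
- Compound 1, `O=c1nc(SCc2ccccc2)ccn1[C@@H]1O[C@H](COP(=O)(O)OP(=O)(O)O)[C@@H](O)[C@H]1O`: 800 nM
- Compound 2, `O=C(O)CCSc1ccn([C@@H]2O[C@H](COP(=O)(O)OP(=O)(O)O)[C@@H](O)[C@H]2O)c(=O)n1`: 1100 nM

Both compounds share the same core and were tested in an in vitro functional assay on 1321-N1 cells for agonist activity at P2Y purinoceptor 6 (Homo sapiens); on this read-out lower numbers stand for an effect already at smaller amounts and higher numbers for an effect only at larger amounts of compound. Within the data shown here, compound 2 gives 1100 nM in this assay, and its only neighbour is compound 1; the step of a 1.4-fold higher number from compound 1 to compound 2 (0.14 log units; within the scatter) lies within the scatter, so the two numbers cannot be told apart.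

Compound 3, `CCSc1ccn([C@@H]2O[C@H](COP(=O)(O)OP(=O)(O)O)[C@@H](O)[C@H]2O)c(=O)n1`, has not yet been measured. It differs from compound 2 in one place: hydrogen in place of carboxy on a saturated chain carbon, two bonds along the chain from a sulfur. Among the measured compounds shown here, no measured step removes a group outright; the only step available, from compound 1 to compound 2, swaps one group for another at a neighbouring position of the same chain and changes nothing beyond the scatter. That step gives no reason to foresee a large shift in this assay, but it also does not cover the loss of a group, so the expectation is uncertain.

Compound 3 is therefore expected to give about 1500 nM in this assay, with a range from 500 nM to 5000 nM, corresponding to an expected step of a 1.4-fold higher number from compound 2 to compound 3 (0.13 log units; within the scatter).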

Compound 3, half-maximal effective concentration: 280 nM
Compound 3: middle estimate off by 5.4-fold (0.73 log units), on the high side, outside the stated range (below it).
By their numbers in this assay, from the lowest: compound 3; then compounds 1 and 2 (each within the scatter of the next).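

The side chain on sulfur turns out to be less forgiving than the first comparison suggested: in this assay, taking the carboxy group off gives a 3.9-fold lower number from compound 2 to compound 3 (0.59 log units; beyond the scatter), a modest step but one beyond the scatter. Swapping phenyl for methyl on the chain carbon bound to the sulfur gives a 2.9-fold lower number from compound 1 to compound 3 (0.46 log units; beyond the scatter), so the plain ethylsulfanyl chain of compound 3 has the lowest number of the three, although the two chain ends in compound 1 and compound 2 could not be told apart. This position therefore does respond to change, since two quite different ends give similar numbers while the unadorned ethyl chain stands clearly apart from both, and no evidence is at hand on what lies behind this difference.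

The compounds shown leave open whether the trend continues with a still smaller methylsulfanyl group or reverses with a longer chain such as propyl. They also leave open how an amine or a hydroxyl at the end of the chain would compare with the carboxy group and with plain hydrogen at that place.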